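Swapping the cyclohexyl tail for a nitrophenyl ring

A few compounds are considered here, and "the series" means these few. Any claim that something is new, unique, unknown or untested is made for them only; others in the source may bear on it.

Measured so far:
compound 1 `Clc1ccccc1Cn1nnc2c(NCC3CCCCC3)ncnc21` 4260 nM
compound 2 `Cc1ccc(Nc2ncnc3c2nnn3Cc2ccccc2Cl)cc1` 119 nM

In an assay on cell membranes for binding affinity to adenosine receptor A1 (Bos taurus), read by radioligand binding (on this read-out lower numbers stand for stronger inhibition and higher numbers for weaker inhibition), compound 1 gives the higher of the two numbers; compound 2 stands a step away, a 36-fold lower number from compound 1 to compound 2 (1.55 log units; beyond the scatter). That step changes the group on the aromatic-ring nitrogen itself, with the 4-methylphenyl sitting directly on the nitrogen, so it bears only loosely on the change now at hand. Compound 3 `O=[N+]([O-])c1ccc(CNc2ncnc3c2nnn3Cc2ccccc2Cl)cc1` keeps the linking chain carbon and differs from compound 1 only in what hangs on it: 4-nitrophenyl in place of cyclohexyl on a saturated chain carbon bound to a nitrogen on an aromatic ring. Compound 1 and compound 2 show that moving from a saturated ring to an aromatic one near this nitrogen can bring a large drop in the number, and a drop in this assay is therefore expected. That drop is expected to be more modest, estimated as a 2.8-fold lower number from compound 1 to compound 3 (0.45 log units; beyond the scatter). Compound 3 is estimated at 1500 nM, with a range from 300 nM to 7000 nM.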

Compound 3, inhibition constant: > 1000 nM
Compound 3 ended at the assay's limit; the forecaster's own chance of this, stated with the estimate: 5%; the middle value does not contradict the limit.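

In this assay compound 3 gives > 1000 nM as a limit of the assay, not a number, so no size can be read for the step from compound 1 to compound 3. From the compounds shown here alone, whether 4-nitrophenyl in place of cyclohexyl lowers the number, raises it or leaves it unchanged stays open.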